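Swapping the hydroxyphenyl of a boron-bearing chalcone

A few compounds are considered here, and "the series" means these few. Any claim that something is new, unique, unknown or untested is made for them only; others in the source may bear on it.

Compound 1, `O=C(/C=C/c1ccc2c(c1)B(O)OC2)c1ccccc1O`, in an ADME assay on L929 cells (Mus musculus) for cytotoxicity, read by resazurin assay, with a stated time of 72 h; a higher number here means a weaker inhibitor, a lower number a stronger inhibitor: > 10 ug/mL, a limit of the assay rather than a number.
Compound 2, `COc1cccc(C(=O)/C=C/c2ccccc2)c1`, in this assay: 5.7 ug/mL.

Compound 1 thus stands only at the limit of this assay, as the limit of > 10 ug/mL in this assay, at which 1 of the 2 values shown sits, shows; no number is known for it. Compound 3, `O=C(/C=C/c1ccc2c(c1)B(O)OC2)c1ccc(Cl)cc1`, differs from compound 1 by 4-chlorophenyl in place of 2-hydroxyphenyl on a carbonyl carbon. Going by the values given here, no measured step joins these two, so the size of the change is expectation alone. In this assay the expected step is an at least 1.1-fold lower number from compound 1 to compound 3 (0.04 log units; that floor lies within the scatter), toward somewhat stronger inhibition, though a limit could again be reported. Compound 3 is estimated at 9 ug/mL, within a range from 4 ug/mL to 25 ug/mL.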

Compound 3, half-maximal inhibitory concentration: > 10 ug/mL
Compound 3: only a limit was reported; the forecaster's own chance of this, stated with the estimate: 45%; middle value at least 1.1-fold (0.04 log units) from the limit.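

In this assay, going by these compounds alone, compound 3 gives > 10 ug/mL, a limit of the assay and not a number, as compound 1 does, so no step between compound 1 and compound 3 can be read. From the compounds shown here alone, whether 4-chlorophenyl in place of 2-hydroxyphenyl on a carbonyl carbon shifts this read-out at all stays open.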